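A swap on the sulfonamide nitrogen of compound 3

The compounds below may be only part of what the source reports. "The series", "measured", "known", "first", "only" and "open" are said of these compounds alone.

Compound 1 (`O=C(/C=C/c1cccnc1)NCCCCCCc1ccc(S(=O)(=O)Nc2ccccc2)cc1`) gives 328 nM
Compound 2 (`O=C(/C=C/c1cccnc1)NCCCc1cccc(S(=O)(=O)Nc2ccccc2)c1`) gives 165 nM
Compound 3 (`Cc1ccccc1NS(=O)(=O)c1cccc(CCCCCCNC(=O)/C=C/c2cccnc2)c1`) gives 2.9 nM

All three values come from a functional assay on DU-145 cells (Homo sapiens) for inhibition, read by CCK-8 assay, with a stated time of 72 h (a higher number here means a weaker inhibitor, a lower number a stronger inhibitor), and compound 3 holds the lowest number (2.9 nM), beyond the scatter from both others, which makes it the strongest inhibitor so far. Compound 4 (`O=C(/C=C/c1cccnc1)NCCCCCCc1cccc(S(=O)(=O)Nc2ccc(F)cc2)c1`) differs from compound 3 in one place (4-fluorophenyl in place of 2-methylphenyl on a sulfonamide nitrogen): 4-fluorophenyl in place of 2-methylphenyl on a sulfonamide nitrogen. For the measured compounds named here, no measured pair shows a change at this spot alone, so the data give no direct guide. With compound 3 at 2.9 nM there is more room to rise than to fall. The expected step is a 3.1-fold higher number from compound 3 to compound 4 (0.49 log units; beyond the scatter) and it points to a moderately weaker inhibitor. For compound 4 the estimate is 9 nM (expected range 1.5 nM to 50 nM).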

Compound 4, half-maximal inhibitory concentration: 10.6 nM
Compound 4: the middle estimate sits 1.2-fold (0.07 log units) below what was measured, within the range that was stated.
By their numbers in this assay, from the lowest: compound 3; then compound 4; then compounds 2 and 1 (each within the scatter of the next).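

Placing 4-fluorophenyl instead of 2-methylphenyl on the sulfonamide nitrogen gives a 3.7-fold higher number from compound 3 to compound 4 (0.56 log units; beyond the scatter), the first direct reading at this position. The step is modest but real, so this spot responds to the aryl group it carries, and a compound with the 4-fluorophenyl group remains far from inactive. Nothing measured here explains the change.

As far as these compounds go, a methyl group leaves and a fluorine enters in the same step, so their separate contributions remain unknown. From the compounds shown here alone, how a pyridine ring or a cyclohexyl group would fare on this nitrogen also remains open.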